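The source may report more compounds than this note shows. Statements on the series, on what has been measured and on what is new or still open speak of the compounds shown alone.

The measured compounds:
compound 1 `CCCNc1nc(C)nc2c1cnn2-c1ccccc1`, which in a functional assay on G-361 cells (Homo sapiens) for cytotoxicity, read by sulforhodamine B assay (a higher number here means a weaker inhibitor of growth, a lower number a stronger inhibitor of growth), gives only a limit, > 100000 nM.
compound 2 `Cc1nc(NC(C)C)c2cnn(-c3ccccc3)c2n1`, which in this assay gives only a limit, > 100000 nM.
compound 3 `CCCNc1nc(CC)nc2c1cnn2-c1ccccc1`, which in this assay gives 37000 nM.

For the measured compounds named here, compound 3 thus stands as the only real number among the three; the other two are limits, and the step of an at least 2.7-fold lower number from compound 1 to compound 3 (0.43 log units; beyond the scatter) is at least modest and beyond the scatter. Compound 4 `CCc1nc(NC(C)C)c2cnn(-c3ccccc3)c2n1` differs from compound 3 by isopropyl in place of propyl on a nitrogen on an aromatic ring. The same change has been measured once, as a step that the two limits leave unreadable from compound 1 to compound 2, but its size is not readable since both of its values sit at the limit of > 100000 nM in this assay, at which 2 of the 3 values shown sit. Going by the values given here, no measured step therefore tells whether this change moves growth inhibition either way. Compound 4 is expected to give 40000 nM, within a range from 15000 nM to 150000 nM. This expected step, a 1.1-fold higher number from compound 3 to compound 4 (0.03 log units; within the scatter), stays within the scatter.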

Compound 4, concentration for total growth inhibition: > 100000 nM
Compound 4 ended at the assay's limit; the forecaster's own chance of this, stated with the estimate: 40%; middle value at least 2.5-fold (0.39 log units) from the limit.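

Isopropyl in place of propyl on a nitrogen on an aromatic ring now has a readable direction in this assay: the change gives an at least 2.7-fold higher number from compound 3 to compound 4 (0.43 log units; beyond the scatter). This size is only a minimum, and the result holds for this one pair. The steps between the other compounds that differ in one place cannot be read, because both values in each are limits: the limit of > 100000 nM in this assay, at which 3 of the 4 values shown sit.

Going by these compounds, how a longer chain on that nitrogen, or a terminal amine on the propyl chain, would act remains open.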